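A few compounds are considered here, and "the series" means these few. Any claim that something is new, unique, unknown or untested is made for them only; others in the source may bear on it.

Compound 1 `Cc1cc(NC(=O)Cn2nnc(-c3ccc(Cl)c(Cl)c3)n2)n(C2CCCCC2)n1`: 84%
Compound 2 `Cc1cc(NC(=O)Cn2nnc(-c3cccc(F)c3)n2)n(C2CCCCC2)n1`: 96%
Compound 3 `Cc1ccc(-c2nnn(CC(=O)Nc3cc(C)nn3C3CCCCC3)n2)cc1`: 86%

In an assay on HEK293 cells for activation of Kir3.1/Kir3.2 (Homo sapiens), read by thallium flux (on this read-out higher numbers stand for larger maximal responses and lower numbers for smaller maximal responses), these three compounds share one core and differ only in the aromatic ring attached to it. Compound 3 stands second highest of the three numbers, yet its gaps to compound 1 and to compound 2 both lie within the scatter, so no order among them is secure. Compound 4 `Cc1cc(NC(=O)Cn2nnc(-c3cccc(C(F)(F)F)c3)n2)n(C2CCCCC2)n1` carries 3-(trifluoromethyl)phenyl in place of 4-methylphenyl on an aromatic carbon. Among the measured compounds shown here, the steps that bear on this change are a number 12 percentage points higher from compound 1 to compound 2 (beyond the scatter), a number 2 percentage points higher from compound 1 to compound 3 (within the scatter) and a number 10 percentage points lower from compound 2 to compound 3 (within the scatter): exchanging one aromatic ring for another has so far moved the maximal response only modestly or not at all. Compound 4 is therefore expected to show a number 4 percentage points higher from compound 3 to compound 4 (within the scatter), nothing beyond the scatter. The estimate for compound 4 is 90%, ranging from 76% to 104%.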

Compound 4, largest response reached (Emax), in percent of the reference or control that the assay uses: 86%
Compound 4: the middle estimate sits 4 percentage points above what was measured; measured number inside the range.
By their numbers in this assay, from the lowest: compounds 1, 3, 4 and 2 (each within the scatter of the next, the first and the last beyond it).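

In this assay, this aromatic carbon on the shared core also accepts 3-(trifluoromethyl)phenyl, with the exchange for 4-methylphenyl giving no change at the digits printed from compound 3 to compound 4 (within the scatter). Trifluoromethyl in place of fluoro gives a number 10 percentage points lower from compound 2 to compound 4 (within the scatter), and the exchange for 3,4-dichlorophenyl gives a number 2 percentage points higher from compound 1 to compound 4 (within the scatter). All the new steps therefore stay within the scatter, and the new group repeats no step beyond it. On these data alone, whether a phenyl ring bearing an amine or a carboxylic acid would keep the maximal response remains open, and no evidence is available on what underlies these values.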